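This account rests on a few compounds, and the source may have more. Where it says the series, first, only, none or still open, it means among the compounds named here.

Compound 1, `CCc1ccc(-c2cc(Cl)cc(C(=O)Nc3nn[nH]n3)n2)cc1`: in a functional assay on the whole organism with Rattus norvegicus as the target, at a dose of 3 mg/kg by the oral route (a higher number here means a stronger effect of the compound at the dose given, a lower number a weaker effect), compound 1 gives 100%.
Compound 2, `CC(C)c1ccc(-c2cc(Cl)cc(C(=O)Nc3nn[nH]n3)n2)cc1`: in this assay compound 2 gives 68%.
Compound 3, `CCCCc1ccc(-c2cc(Cl)cc(C(=O)Nc3nn[nH]n3)n2)cc1`: in this assay compound 3 gives 83%.

Compound 3 stands second highest of the three numbers: a number 15 percentage points higher from compound 2 to compound 3 (beyond the scatter), while a number 17 percentage points lower from compound 1 to compound 3 (beyond the scatter).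

Compound 4, `Nc1ccc(-c2cc(Cl)cc(C(=O)Nc3nn[nH]n3)n2)cc1`, differs from compound 3 by amino in place of butyl on an aromatic carbon. The measured steps all change one saturated chain into another on that aromatic carbon: a number 32 percentage points lower from compound 1 to compound 2 (beyond the scatter), a number 17 percentage points lower from compound 1 to compound 3 (beyond the scatter) and a number 15 percentage points higher from compound 2 to compound 3 (beyond the scatter). None of them puts amino in place of a chain, so they bear on this change only loosely; they show that changes on that carbon move this assay by modest to large steps in either direction. Compound 4 is therefore expected to move beyond the scatter, most likely downward, a number 28 percentage points lower from compound 3 to compound 4 (beyond the scatter). Compound 4 is estimated at 55%, within 20% to 90%.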

Compound 4, a percentage reported as inhibition, in the whole organism at one dose (the size of the read-out at that dose, not a potency): 100%
Compound 4: middle estimate off by 45 percentage points, on the low side; measured number above the stated range.
By their numbers in this assay, from the lowest: compound 2; then compound 3; then compounds 1 and 4 (each within the scatter of the next).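

In this assay amino in place of butyl gives a number 17 percentage points higher from compound 3 to compound 4 (beyond the scatter) and amino in place of isopropyl gives a number 32 percentage points higher from compound 2 to compound 4 (beyond the scatter) while amino in place of ethyl gives no change at the digits printed from compound 1 to compound 4 (within the scatter) on the same aromatic carbon, para to a large group. A saturated chain is therefore not required there for the effect at this dose, and the single nitrogen of amino serves as well as ethyl. The earlier compounds shown here, all bearing chains, could not show this.

On these data alone, whether a methylamino group, a hydroxyl or a carboxylic acid at this carbon would keep the effect stays open. So does whether compound 1 and compound 4 would separate at a lower dose, and no evidence given here accounts for these steps.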